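This account rests on a few compounds, and the source may have more. Where it says the series, first, only, none or still open, it means among the compounds named here.

In a functional assay on H9c2 cells (Mus musculus) for cytotoxicity against H9c2 (Rattus norvegicus), read by MTT assay, with a stated time of 24 h (a lower number here means that less compound is needed, a higher number that more compound is needed for the effect), compound 1 `COc1ccccc1Cc1coc2cccc(O)c2c1=O` is reported only as a limit, > 100000 nM. Compound 2 `COc1ccc(Cc2coc3cc(OC)cc(OC)c3c2=O)cc1` likewise reaches only a limit, > 100000 nM. Among the compounds with values here, compound 3 `COc1cc(OC)c2c(=O)c(Cc3ccc(Cl)c(Cl)c3)coc2c1` is the single compound with a number, 23800 nM, so it stands apart from the limit of > 100000 nM in this assay, at which 2 of the 3 values shown sit. Within the data shown here, the one measured step, an at least 4.2-fold lower number from compound 2 to compound 3 (0.62 log units; beyond the scatter), came from putting the 3,4-dichlorophenyl in. Compound 4 `COc1cc(OC)c2c(=O)c(Cc3cccs3)coc2c1` now takes that group out again: thiophen-2-yl in place of 3,4-dichlorophenyl on a saturated chain carbon bound to an aromatic carbon. Among the measured compounds shown here, since the only step that bears on this position, an at least 4.2-fold lower number from compound 2 to compound 3 (0.62 log units; beyond the scatter), rewarded the 3,4-dichlorophenyl, removing it is expected to move the number back up, possibly to the limit. Compound 4 is therefore estimated at 70000 nM, within 20000 nM to 250000 nM. The expected step of a 2.9-fold higher number from compound 3 to compound 4 (0.47 log units; beyond the scatter) is toward a higher number.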

Compound 4, half-maximal effective concentration: 74300 nM
Compound 4: the middle estimate sits 1.1-fold (0.03 log units) below what was measured; the measured number falls inside the stated range.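

With thiophen-2-yl, this position gives a second real number, so two ring groups can now be compared directly in this assay: the change produces a 3.1-fold higher number from compound 3 to compound 4 (0.49 log units; beyond the scatter). The smaller sulfur-containing ring therefore does not keep the lower number seen with 3,4-dichlorophenyl. Against 4-methoxyphenyl, thiophen-2-yl gives an at least 1.3-fold lower number from compound 2 to compound 4 (0.12 log units; that floor lies within the scatter), so no real difference can be claimed from this comparison, which rests on a limit: the limit of > 100000 nM in this assay, at which 2 of the 4 values shown sit.

Going by these compounds, this change alters the ring and removes both chlorine atoms together, so their separate contributions remain open. On these data alone, how an amine, a carboxylic acid or a longer chain would read in this place also stays open.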